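Furyl dihydropyrimidinone esters: ring-substituent and ester-alkyl changes

This account rests on a few compounds, and the source may have more. Where it says the series, first, only, none or still open, it means among the compounds named here.

Measured compounds:
compound 1, `CCOC(=O)C1=C(CC)NC(=O)NC1c1ccco1`: 29%
compound 2, `CCCC1=C(C(=O)OCC)C(c2ccco2)NC(=O)N1`: 50%
compound 3, `CCOC(=O)C1=C(C)N(C)C(=O)NC1c1ccco1`: 17%

All three were tested in an assay on CHO cells for displacement of a labelled ligand from adenosine receptor A1 (Homo sapiens), with a stated time of 60 min, tested at 10 uM; on this read-out lower numbers stand for less inhibition and higher numbers for more inhibition at the one concentration tested (going by the name of the read-out). Compound 2 shows the highest number of the three, compound 3 the lowest, and compound 1 stands between them.

For the measured compounds named here, the one measured step is a number 21 percentage points higher from compound 1 to compound 2 (beyond the scatter). The change is methyl in place of hydrogen on a saturated chain carbon, two bonds along the chain from a double-bonded ring carbon.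

Compound 4, `CC1=C(C(=O)OC(C)C)C(c2ccco2)NC(=O)N1C`, is not yet measured. It differs from compound 3 by methyl in place of hydrogen on a saturated chain carbon bound to an oxygen next to a carbonyl group and a saturated chain carbon. Relative to the step from compound 1 to compound 2 this is the same kind of change, a methyl entering for a hydrogen, but at a different place: there on a saturated chain carbon two bonds along the chain from a double-bonded ring carbon, here on a saturated chain carbon bound to an oxygen next to a carbonyl group and a saturated chain carbon. The difference between the core of compound 3 and the core of compound 1 is not broken down here.

Since the measured precedent sits at another place and on another core, the expected step for compound 4 is smaller: the estimate is a number 8 percentage points higher from compound 3 to compound 4 (within the scatter), resting on compound 3 at 17% and the earlier step of a number 21 percentage points higher from compound 1 to compound 2 (beyond the scatter). Compound 4 is therefore expected at 25%, with a range from 10% to 42%.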

Compound 4, a percentage reported as inhibition, at one concentration (the size of the read-out at that concentration, not a potency): 28%
Estimate against measurement, compound 4: 3 percentage points below; the measured number falls inside the stated range.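

Methyl in place of hydrogen gives a number 11 percentage points higher from compound 3 to compound 4 (beyond the scatter) in this assay, so the number moves the same way on the core of compound 3 as on the core of compound 1, and no difference in the size of the two steps can be claimed: the same change on two cores in this assay, a number 21 percentage points higher (beyond the scatter) from compound 1 to compound 2 and a number 11 percentage points higher (beyond the scatter) from compound 3 to compound 4, 10 percentage points apart, within the scatter of two such steps. This is not evidence that the change carries over unaltered from core to core, since each core offers a single pair and the methyl enters at a different place in each: on the core of compound 3 it sits on a saturated chain carbon bound to an oxygen next to a carbonyl group and a saturated chain carbon. The effects of core and place therefore remain unseparated, and a reading at one concentration gives no potency.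

Still open, on these data alone, is how the isopropoxycarbonyl group behaves on the core of compound 1, where the comparison would hold the place fixed. Also open, as far as these compounds go, is whether a longer chain on the ester oxygen, or a carboxylic acid or an amine in place of the ester, follows the same direction.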